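The source may hold more compounds than are shown below. What is called first, only, known or untested is meant among the compounds shown, and "the series" means these compounds.

Of the compounds shown here, two have so far been measured in a functional assay on PC-9 cells (Homo sapiens) for inhibition, read by MTT assay, with a stated time of 72 h; on this read-out higher numbers stand for weaker inhibition and lower numbers for stronger inhibition. Compound 1 `Cc1cc(Nc2cc(-c3ccccc3)[nH]n2)n2nc(SCc3ccc(F)cc3)nc2n1` gives 8110 nM, and compound 2 `Cc1cc(Nc2cc(-c3ccccc3)[nH]n2)n2nc(SCc3cccc4ccccc34)nc2n1` gives 3950 nM. They share one core and differ only in the group on a saturated chain carbon bound to a sulfur: a 2.1-fold lower number from compound 1 to compound 2 (0.31 log units; beyond the scatter). Among the measured compounds shown here, on these numbers compound 2 stands lowest of the two, with compound 1 as its only neighbour.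

Compound 3 `Cc1cc(Nc2cc(-c3ccccc3)[nH]n2)n2nc(SCC3CC3)nc2n1` has not yet been measured and differs from compound 2 as follows: cyclopropyl in place of naphthalen-1-yl on a saturated chain carbon bound to a sulfur. For the measured compounds named here, the only measured step that bears on this change is the one from compound 1 to compound 2, where two fused six-membered aromatic rings replaced a single one and the number fell modestly. Going by the values given here, compound 3 goes the other way, to a three-membered non-aromatic ring of carbon only, and no measured pair covers such a group, so the expectation rests on extrapolation alone. Compound 3 is therefore expected to show a 2.0-fold higher number from compound 2 to compound 3 (0.31 log units; beyond the scatter). The estimate for compound 3 is 8000 nM, within a range from 3000 nM to 25000 nM.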

Compound 3, half-maximal inhibitory concentration: > 50000 nM
Compound 3: a limit, no number; the forecaster's own chance of this, stated with the estimate: 10%; middle value at least 6.2-fold (0.79 log units) from the limit.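

In this assay the entry for compound 3 is a limit of the assay and not a number: the limit of > 50000 nM in this assay, at which 1 of the 3 values shown sits. Even so, the new steps show that this place, on a saturated chain carbon bound to a sulfur, matters far more than the first pair suggested: cyclopropyl in place of naphthalen-1-yl gives an at least 12-fold higher number from compound 2 to compound 3 (1.10 log units; beyond the scatter), and cyclopropyl in place of 4-fluorophenyl gives an at least 6.1-fold higher number from compound 1 to compound 3 (0.78 log units; beyond the scatter), whereas the exchange of one aromatic group for the other gave only a 2.1-fold lower number from compound 1 to compound 2 (0.31 log units; beyond the scatter). Among these three compounds, then, both groups with aromatic rings give readable numbers, and the one with a small non-aromatic ring reaches the limit.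

Cyclopropyl differs from the two aromatic groups both in having no aromatic ring and in having fewer heavy atoms, so these compounds cannot tell which of the two differences counts. A cyclohexyl group would keep a larger ring without aromatic character, and a plain phenyl or a longer chain in the same place would help to separate the two, while an amine would test a different kind of group altogether.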